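A few compounds are considered here, and "the series" means these few. Any claim that something is new, unique, unknown or untested is made for them only; others in the source may bear on it.

Compound 1 `CCc1c(OC)nc2nc(-c3noc(C)n3)c(Cl)n2c1C`: 10 mg/kg
Compound 2 `CCc1c(OC)nc2nc(-c3nc(C)cs3)cn2c1C`: > 50 mg/kg
Compound 3 `CCc1c(OC)nc2nc(-c3nc(C)c(C)s3)cn2c1C`: > 50 mg/kg

In a functional assay on the whole organism with Rattus norvegicus as the target (on this read-out lower numbers stand for an effect already at smaller amounts and higher numbers for an effect only at larger amounts of compound), compound 1 gives a number, whereas the other two compounds reach only the limit of the assay. Compound 3 sits at that limit (the limit of > 50 mg/kg in this assay, at which 2 of the 3 values shown sit), so it has no number of its own. Going by the values given here, the one measured step, a step that the two limits leave unreadable from compound 2 to compound 3, runs between two limits and is therefore unreadable. Compound 4 `CCc1c(OC)nc2nc(-c3cnco3)cn2c1C` differs from compound 3 by 1,3-oxazol-5-yl in place of 4,5-dimethyl-1,3-thiazol-2-yl on an aromatic carbon. No measured step covers a change of this kind, and the only step shown gives no size at all, so there is no basis for expecting a large move in either direction. Compound 4 is therefore estimated at 50 mg/kg, with a range from 15 mg/kg to 150 mg/kg, and the expected step of a number no higher from compound 3 to compound 4 (the limit leaves the size open) is small.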

Compound 4, minimum effective dose: > 50 mg/kg
Compound 4: only a limit was reported; the forecaster's own chance of this, stated with the estimate: 60%; the middle value lies on the limit itself.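

Compound 4 also reaches only a limit in this assay, so its steps to compound 2 and compound 3 cannot be read. What stays open is the real size of any difference among these three compounds, none of which has a number of its own.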